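Ester in place of amine on the chromone side chain

The source may hold more compounds than are shown below. What is called first, only, known or untested is meant among the compounds shown, and "the series" means these compounds.

Three compounds share a chromone-like core carrying a di-tert-butyl phenol or its methyl ether, and differ mainly in the chain attached to an oxygen on the aromatic ring. Compound 1 `CC(C)(C)c1cc(-c2cc(=O)c3ccc(OCC(=O)N4CCN(Cc5ccccc5)CC4)cc3o2)cc(C(C)(C)C)c1O` gives 3000 nM in a functional assay for inhibition; on this read-out higher numbers stand for weaker inhibition and lower numbers for stronger inhibition. Compound 2 `CN(C)CCCOc1ccc2c(=O)cc(-c3cc(C(C)(C)C)c(O)c(C(C)(C)C)c3)oc2c1` gives 700 nM in this assay, the lowest of the two numbers shown; compound 1 sits at a higher number, a gap beyond the scatter. Compound 3 `COc1ccc2c(=O)cc(-c3cc(C(C)(C)C)c(OC)c(C(C)(C)C)c3)oc2c1` reaches only a limit of the assay, > 100000 nM in this assay; this is stated as the limit of > 100000 nM in this assay, at which 1 of the 3 values shown sits.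

Compound 4 `CCCCCOC(=O)COc1ccc2c(=O)cc(-c3cc(C(C)(C)C)c(O)c(C(C)(C)C)c3)oc2c1` has not yet been measured in this assay. It differs from compound 2 by pentyloxycarbonyl in place of 2-(dimethylamino)ethyl on a saturated chain carbon bound to an oxygen on an aromatic ring. Within the data shown here, no step between measured compounds follows this exact change, so the account cannot lean on a measured precedent; it can only note that compound 2 carries the dimethylamino chain and stands at 700 nM, while compound 1, with its different side chain, stands at 3000 nM.

The expectation is a step toward weaker inhibition in this assay, of moderate size, a 5.7-fold higher number from compound 2 to compound 4 (0.76 log units; beyond the scatter). Compound 4 is therefore estimated at 4000 nM, within a range from 1000 nM to 20000 nM.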

Compound 4, half-maximal inhibitory concentration: 5000 nM
Estimate against measurement, compound 4: 1.3-fold (0.10 log units) below; the measured number falls inside the stated range.
By their numbers in this assay, from the lowest: compound 2; then compounds 1 and 4 (each within the scatter of the next). At a limit, above all of these: compound 3.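

In this assay, replacing 3-(dimethylamino)propoxy with (pentyloxycarbonyl)methoxy on the shared core gives a 7.1-fold higher number from compound 2 to compound 4 (0.85 log units; beyond the scatter), which shows that inhibition responds to the identity of the chain at this position, and that this ester chain does not match the dimethylamino chain of compound 2. The values of compound 1 and compound 4 lie within the scatter of each other, so the two chains that carry a carbonyl, one ending in the pentyl ester and the other in the larger ring-bearing amide, cannot be told apart in this assay. Nothing measured here accounts for the step, so no cause can be given for it.

This single change removes the dimethylamino nitrogen, brings in the ester and alters the chain as a whole, so the compounds shown cannot separate these contributions. On these data alone, it remains open how a carboxylic acid in place of the pentyl ester, a simple pentyl amide, or a dimethylamino chain of a different length would stand at this position.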